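Removing the benzimidazole N-methyl in a prolinamide orexin-2 series

The source may report more compounds than this note shows. Statements on the series, on what has been measured and on what is new or still open speak of the compounds shown alone.

Measured so far, in an assay on CHO cells for displacement of a labelled ligand from Orexin receptor type 2 (Homo sapiens); a higher number here means a weaker inhibitor, a lower number a stronger inhibitor:
compound 1 `Cc1ccc2[nH]c(SCC(=O)N3CCC[C@H]3C(=O)Nc3ccccc3-n3cccc3)nc2c1`: 0.2 nM
compound 2 `Cn1c(CCC(=O)N2CCC[C@H]2C(=O)Nc2ccccc2-c2ccccc2)nc2ccccc21`: 0.8 nM
compound 3 `Cc1ccc2c(c1)nc(SCC(=O)N1CCC[C@H]1C(=O)Nc1ccccc1-n1cccc1)n2C`: 0.09 nM

Compound 2 gives the highest of the three numbers, with compound 1 nearest and compound 3 furthest. The difference between the core of compound 2 and the core of compound 3 is not broken down here.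

One change occurs twice in the set. From compound 3 to compound 1 it is hydrogen in place of methyl on an aromatic nitrogen, and the step it made in this assay was a 2.2-fold higher number from compound 3 to compound 1 (0.35 log units; beyond the scatter).

Compound 4 `O=C(Nc1ccccc1-c1ccccc1)[C@@H]1CCCN1C(=O)CCc1nc2ccccc2[nH]1`, not yet measured, differs from compound 2 by hydrogen in place of methyl on an aromatic nitrogen, the same change at the same place. Going by the values given here, for compound 4 the step is estimated as a 2.3-fold higher number from compound 2 to compound 4 (0.35 log units; beyond the scatter), resting on compound 1 and its step of a 2.2-fold higher number from compound 3 to compound 1 (0.35 log units; beyond the scatter); the second pair of compounds supplies the only precedent, so the expectation is held loosely. Compound 4 is thus expected to give about 1.8 nM in this assay, estimated to lie between 0.8 nM and 4.5 nM.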

Compound 4, inhibition constant: 6 nM
Compound 4: the middle estimate sits 3.3-fold (0.52 log units) below what was measured; measured number outside the range, above it.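

In this assay, hydrogen in place of methyl on the aromatic nitrogen gives a higher number on both cores, and the new step is a 7.5-fold higher number from compound 2 to compound 4 (0.88 log units; beyond the scatter). The direction carries from one core to the other, but the size does not: the same change on two cores in this assay, a 2.2-fold higher number (0.35 log units; beyond the scatter) from compound 3 to compound 1 and a 7.5-fold higher number (0.88 log units; beyond the scatter) from compound 2 to compound 4, 3.4-fold (0.53 log units) apart, beyond the scatter of two such steps

These two pairs do not show which part of the cores sets the size of the step, and they give no rule for a third core. Still open, from the compounds shown here alone, is how the step reads on a core that differs from the core of compound 2 in one place only. Also open, going by these compounds, is how an ethyl or a methoxyethyl group on the same nitrogen compares with methyl and hydrogen.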